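Toward compound 4: methylsulfonyl on the phenyl group

The source may report more compounds than this note shows. Statements on the series, on what has been measured and on what is new or still open speak of the compounds shown alone.

In a functional assay for inhibition, with Rattus norvegicus as the target (on this read-out lower numbers stand for stronger inhibition and higher numbers for weaker inhibition), compound 3 `CC(/N=c1\c(O)c(O)\c1=N/c1ccccc1)C(C)(C)C` gives 5400 nM, the lower of the two actual numbers in the series. Its nearest neighbour is compound 2 `CC(/N=c1\c(O)c(O)\c1=N/c1cncc(Br)c1)C(C)(C)C` at 11700 nM. Compound 1 `CC(/N=c1\c(O)c(O)\c1=N/c1cccnc1O)C(C)(C)C` reads > 30000 nM, which is a limit of the assay and not a number.

Compound 4 `CC(/N=c1\c(O)c(O)\c1=N/c1ccc(S(C)(=O)=O)cc1)C(C)(C)C` differs from compound 3 by one change: methylsulfonyl in place of hydrogen on an aromatic carbon, para to a large group (methylsulfonyl in place of hydrogen on an aromatic carbon). Going by the values given here, no measured step adds a group to the phenyl of compound 3, so the evidence is indirect. The available steps exchange the whole aromatic group. Phenyl in place of 2-hydroxypyridin-3-yl gives an at least 5.5-fold lower number from compound 1 to compound 3 (0.74 log units; beyond the scatter), and phenyl in place of 5-bromopyridin-3-yl gives a 2.2-fold lower number from compound 2 to compound 3 (0.34 log units; beyond the scatter). Among these three compounds, unsubstituted phenyl carries the lowest number, and none goes against this. Neither of the other two aromatic groups resembles methylsulfonyl-bearing phenyl, so this pattern is only a weak guide. A modest step towards a higher number in this assay is therefore expected. The estimated change is a 2.0-fold higher number from compound 3 to compound 4 (0.31 log units; beyond the scatter). For compound 4 the estimate is 11000 nM, with an expected range of 3500 nM to 30000 nM.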

Compound 4, half-maximal inhibitory concentration: > 30000 nM
Compound 4 gave a limit, no number; the forecaster's own chance of this, stated with the estimate: 20%; at least 2.7-fold (0.43 log units) between middle value and limit.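

Going by these compounds alone, this is the first measured step that adds a group to the phenyl of compound 3 and does not exchange the whole aromatic group: in this assay, methylsulfonyl in place of hydrogen on an aromatic carbon, para to a large group, gives an at least 5.5-fold higher number from compound 3 to compound 4 (0.74 log units; beyond the scatter). Compound 4 stands at a limit of the assay and not at a number: the limit of > 30000 nM in this assay, at which 2 of the 4 values shown sit.

Unsubstituted phenyl in compound 3 now carries the lowest number among all four compounds, none of them goes against this, and a single addition to that phenyl proves enough to reach the same limit that the exchange of the aromatic group reached in compound 1.

Going by these compounds, how far the number for compound 4 lies from that of compound 3 stays open, and so does the question whether this place accepts any addition at all: methyl, fluorine, an amine or a carboxylic acid on the same aromatic carbon could each show whether a number in this assay survives. Also open, on these data alone, is whether methylsulfonyl at another carbon of the phenyl leads to the same limit.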